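Allyl for benzyl in the quaternary anilinium series

The source may hold more compounds than are shown below. What is called first, only, known or untested is meant among the compounds shown, and "the series" means these compounds.

Compound 2 `COc1cccc([N+](C)(C)Cc2ccccc2)c1` and compound 1 `C=CC[N+](C)(C)c1cccc(OC)c1` share one core; compound 1 arises from compound 2 by vinyl in place of phenyl on a saturated chain carbon bound to a nitrogen on an aromatic ring. In a functional assay with Cavia porcellus as the target (on this read-out lower numbers stand for stronger inhibition and higher numbers for weaker inhibition), compound 2 gives only a limit, > 3000 nM. Compound 1 likewise gives only a limit in this assay, > 3000 nM. The step that the two limits leave unreadable from compound 2 to compound 1 is therefore of unreadable size, because of the limit of > 3000 nM in this assay, at which 2 of the 3 values shown sit.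

Compound 3 `COc1ccc(C(=O)COc2ccc([N+](C)(C)Cc3ccccc3)cc2)cc1OC` carries a larger core; how it differs from the core of compound 2 is not broken down here. In this assay, among the compounds with values here, compound 3 gives 19400 nM, the only number among the three values shown. Compound 4 `C=CC[N+](C)(C)c1ccc(OCC(=O)c2ccc(OC)c(OC)c2)cc1` is reached from compound 3 by the same change, (vinyl in place of phenyl on a saturated chain carbon bound to a nitrogen on an aromatic ring); the change occurs twice within the set.

Within the data shown here, what the step from compound 3 to compound 4 may do in this assay rests on nothing readable: the single measured instance of this change sits between two limits, and the same place is involved in both cases. A step within the usual scatter is expected, a 1.0-fold lower number from compound 3 to compound 4 (0.01 log units; within the scatter). For compound 4 the estimate is 19000 nM, between 7000 nM and 50000 nM.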

Compound 4, half-maximal inhibitory concentration: 500 nM
Beside the measured number, compound 4's estimate is 38-fold (1.58 log units) above it, outside the stated range (below it).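

Notes on benzyl to allyl: on the larger core, in this assay, the change gives a large step beyond the scatter (a 39-fold lower number from compound 3 to compound 4 (1.59 log units; beyond the scatter)). On the core of compound 2 the same change cannot be read, because compound 2 and compound 1 each give a limit of the assay and not a number: (the limit of > 3000 nM in this assay, at which 2 of the 4 values shown sit). The series therefore holds one readable instance of the change, which shows its size on the larger core only and does not show that the change carries from one core to another.

The compounds shown leave open whether the step depends on the double bond of allyl or only on the departure of the phenyl ring, and a propyl group in the same place on the larger core would separate the two. Also open, on these data alone, is how far the step depends on the larger core, as the core of compound 2 offers no number on either side of the change.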